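Replacing an open amino chain with 4-aminocyclohexyl

The source may hold more compounds than are shown below. What is called first, only, known or untested is meant among the compounds shown, and "the series" means these compounds.

Measured in an ADME assay on the whole organism (strain FVB) for pharmacokinetics, with Mus musculus as the target, read by LC-MS, at a dose of 30 mg/kg by the oral route; on this read-out higher numbers stand for higher exposure at the dose given and lower numbers for lower exposure:
Compound 1 `NCCOc1ccc([C@H]2CC[C@]3(CC2)OOC2(O3)C3CC4CC(C3)CC2C4)cc1`: 1370 ng.h/mL
Compound 2 `CC(C)(O)CNCCCOc1ccc([C@H]2CC[C@]3(CC2)OOC2(O3)C3CC4CC(C3)CC2C4)cc1`: 11100 ng.h/mL
Compound 3 `CC(C)(N)CCOc1ccc([C@H]2CC[C@]3(CC2)OOC2(O3)C3CC4CC(C3)CC2C4)cc1`: 12300 ng.h/mL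

Compound 3 sits at the upper end of this small set. It cannot be told apart from its nearest neighbour, a 1.1-fold higher number from compound 2 to compound 3 (0.04 log units; within the scatter), and it stands well clear of the lowest value, a 9.0-fold higher number from compound 1 to compound 3 (0.95 log units; beyond the scatter).

Compound 4 `N[C@H]1CC[C@@H](Oc2ccc([C@H]3CC[C@]4(CC3)OOC3(O4)C4CC5CC(C4)CC3C5)cc2)CC1` keeps the shared core and alters only the side group: 4-aminocyclohexyl in place of 3-amino-3-methylbutyl on an oxygen on an aromatic ring.

Among the compounds with values here, no measured step brings in a ring at this place, so the evidence is indirect. Within the data shown here, two steps bear on it. Both replace the amino group of compound 1 with a larger group, and they are similar in size: an 8.1-fold higher number from compound 1 to compound 2 (0.91 log units; beyond the scatter) and a 9.0-fold higher number from compound 1 to compound 3 (0.95 log units; beyond the scatter). Two quite different groups in compound 2 and compound 3 thus give values within the scatter of each other, as a 1.1-fold higher number from compound 2 to compound 3 (0.04 log units; within the scatter) shows. A large move is therefore not expected, and a slight loss is the expected direction: a 1.5-fold lower number from compound 3 to compound 4 (0.19 log units; within the scatter). For compound 4 the estimated value is 8000 ng.h/mL, with an expected range of 2500 ng.h/mL to 22000 ng.h/mL.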

Compound 4, area under the concentration-time curve: 13400 ng.h/mL
Beside the measured number, compound 4's estimate is 1.7-fold (0.22 log units) below it; the measured number falls inside the stated range.
By their numbers in this assay, from the lowest: compound 1; then compounds 2, 3 and 4 (each within the scatter of the next).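

In this assay, a 1.1-fold higher number from compound 3 to compound 4 (0.04 log units; within the scatter) and a 1.2-fold higher number from compound 2 to compound 4 (0.08 log units; within the scatter) show that a side group closed into a six-membered ring of carbon only cannot be told apart from the two open chains on this oxygen on an aromatic ring. With a 9.8-fold higher number from compound 1 to compound 4 (0.99 log units; beyond the scatter) as the step from the 2-aminoethyl group, the ring keeps the whole rise that the open chains had already given, so this position is not limited to open chains among the compounds shown. Nothing available here explains why these three different groups give such similar exposure.

The compounds shown leave open how the other stereoisomer of the 4-aminocyclohexyl group would read. They also leave open whether a piperidine, with the nitrogen inside the ring, or a hydroxyl group in place of the amine would give similar exposure.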